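Methyl for Methoxy: What to Expect for Compound 4

The source may report more compounds than this note shows. Statements on the series, on what has been measured and on what is new or still open speak of the compounds shown alone.

Compound 1 `COc1ccc2[nH]c(-c3ccc[nH]3)c(C3CC(=O)NC3=O)c2c1` and compound 3 `Cc1ccc2[nH]c(-c3ccc[nH]3)c(C3CC(=O)NC3=O)c2c1` share one core and differ in a single place: methyl in place of methoxy on an aromatic carbon. In a functional assay on MCF7 cells (Homo sapiens) for cytotoxicity, read by MTT assay, with a stated time of 72 h (a higher number here means a weaker inhibitor, a lower number a stronger inhibitor), compound 1 gives 19000 nM, and compound 3 gives 29000 nM. The step of a 1.5-fold higher number from compound 1 to compound 3 (0.18 log units; within the scatter) shows that this exchange leaves the activity where it was.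

Compound 2 `COc1ccc2[nH]c(-n3cccn3)cc2c1` is built on a different core; how it differs from compound 1 is not broken down here. In this assay compound 2 gives > 100000 nM, which is a limit of the assay and not a number, as recorded in the limit of > 100000 nM in this assay, at which 1 of the 3 values shown sits.

Compound 4 `Cc1ccc2[nH]c(-n3cccn3)cc2c1` arises from compound 2 by the same change, (methyl in place of methoxy on an aromatic carbon), at the same place. Because the measured step of a 1.5-fold higher number from compound 1 to compound 3 (0.18 log units; within the scatter) stayed within the usual scatter, the step that the limit leaves unreadable from compound 2 to compound 4 is expected to be just as small. Compound 4 is therefore expected to come out near 150000 nM in this assay, within a range from 60000 nM to 400000 nM, and most likely to be reported again only as a limit rather than a number.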

Compound 4, half-maximal inhibitory concentration: > 100000 nM
Compound 4: a limit, no number; the forecaster's own chance of this, stated with the estimate: 85%; the middle value does not contradict the limit.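

In this assay compound 4 gives > 100000 nM as a limit of the assay and not a number. Compound 2 sits at that same limit, so no step can be read between compound 2 and compound 4: the limit of > 100000 nM in this assay, at which 2 of the 4 values shown sit.

The compounds shown leave open whether methyl in place of methoxy changes the activity on the core of compound 2.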